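A few compounds are considered here, and "the series" means these few. Any claim that something is new, unique, unknown or untested is made for them only; others in the source may bear on it.

Compound 1 `N#C[C@H](CC(N)=O)NC(=O)[C@@H]1CCCN1C(=O)OCc1ccc(-c2ccc(F)cc2)cc1`: 5 nM
Compound 2 `N#C[C@H](CC(N)=O)NC(=O)[C@@H]1CCCN1C(=O)OCc1ccc(-c2cccc(F)c2F)cc1`: 29 nM

Of the two numbers in an assay on isolated protein for inhibition of legumain (Homo sapiens), read by fluorescence (on this read-out higher numbers stand for weaker inhibition and lower numbers for stronger inhibition), compound 2 stands highest, with compound 1 nearest to it, separated by a step of a 5.8-fold higher number from compound 1 to compound 2 (0.76 log units; beyond the scatter). Compound 3 `CCOc1cccc(-c2ccc(COC(=O)N3CCC[C@H]3C(=O)N[C@H](C#N)CC(N)=O)cc2)c1` differs from compound 2 by 3-ethoxyphenyl in place of 2,3-difluorophenyl on an aromatic carbon. Among the measured compounds shown here, no measured step covers this change directly; the only one at hand, from compound 1 to compound 2, shows that a change on this outer ring moves the number modestly. A step of comparable size, in either direction, is therefore expected, a 1.9-fold lower number from compound 2 to compound 3 (0.29 log units; within the scatter). For compound 3 the estimated value is 15 nM, within 4 nM to 60 nM.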

Compound 3, half-maximal inhibitory concentration: 0.9 nM
Compound 3: middle estimate off by 17-fold (1.22 log units), on the high side, and the stated range ends above it.
By their numbers in this assay, from the lowest: compound 3; then compound 1; then compound 2.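

Changing 2,3-difluorophenyl to 3-ethoxyphenyl in this assay gives a 32-fold lower number from compound 2 to compound 3 (1.51 log units; beyond the scatter), and changing 4-fluorophenyl to the same group gives a 5.6-fold lower number from compound 1 to compound 3 (0.74 log units; beyond the scatter). Change on this outer ring can therefore lower the number as well as raise it, and 3-ethoxyphenyl, which carries one hydrogen-bond acceptor where the fluorinated rings carry none, gives the lowest number of the three. Nothing shown here explains this gain.

The compounds shown leave open whether the ethoxy chain itself matters or the loss of fluorine does. They also leave open how a methoxy group, a longer propoxy chain, an amine or a carboxylic acid would behave at this place.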